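This account rests on a few compounds, and the source may have more. Where it says the series, first, only, none or still open, it means among the compounds named here.

Compound 3, whose structure is `CCc1ccccc1C1C(=O)N(C)c2cnc(Nc3ccc(S(N)(=O)=O)cc3)nc2N1C`, gives 51 nM in an assay on Sf9 cells for inhibition of serine/threonine-protein kinase 4 (Homo sapiens), read by luminescence and ADP-Glo, with a stated time of 1 h, in the presence of a further agent that is not named here (on this read-out lower numbers stand for stronger inhibition and higher numbers for weaker inhibition), the lowest of the three numbers recorded. Compound 2, `CN1C(=O)C(c2ccccc2F)N(C)c2nc(Nc3ccc(S(N)(=O)=O)cc3)ncc21`, gives 75 nM, and a 1.5-fold lower number from compound 2 to compound 3 (0.17 log units; within the scatter), so the two cannot be ranked against each other. Compound 1, `COc1cccc(C2C(=O)N(C)c3cnc(Nc4ccc(S(N)(=O)=O)cc4)nc3N2C)c1`, gives 954 nM, and a 19-fold lower number from compound 1 to compound 3 (1.27 log units; beyond the scatter); likewise a 13-fold lower number from compound 1 to compound 2 (1.10 log units; beyond the scatter).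

Compound 4, `CN1C(=O)C(Cc2ccccc2)N(C)c2nc(Nc3ccc(S(N)(=O)=O)cc3)ncc21`, is compared with compound 3 by a single change: benzyl in place of 2-ethylphenyl on a saturated ring carbon. The measured steps that bear on this change are the two that alter the group on the same saturated ring carbon, both large and both moving the number sharply downward when the 3-methoxyphenyl is exchanged for an ortho-substituted phenyl. Among the measured compounds shown here, they show that this position is sensitive, but none of the measured compounds carries a benzyl, so the direction of the present step is not fixed by the data. Because the downward steps a 19-fold lower number from compound 1 to compound 3 (1.27 log units; beyond the scatter) and a 13-fold lower number from compound 1 to compound 2 (1.10 log units; beyond the scatter) were obtained with groups quite unlike benzyl, the more cautious expectation is that compound 4 gives up part of that gain, with a 5.9-fold higher number from compound 3 to compound 4 (0.77 log units; beyond the scatter) expected. Compound 4 is therefore estimated at 300 nM, within a range from 80 nM to 1200 nM.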

Compound 4, half-maximal inhibitory concentration: > 10000 nM
Compound 4 ended at the assay's limit; the forecaster's own chance of this, stated with the estimate: 5%; middle value at least 33-fold (1.52 log units) away from the limit.
By their numbers in this assay, from the lowest: compounds 3 and 2 (each within the scatter of the next); then compound 1. At a limit, above all of these: compound 4.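

Compound 4 stands at a limit of the assay and not at a number, in this assay: the limit of > 10000 nM in this assay, at which 1 of the 4 values shown sits.

The earlier compounds shown here showed that this saturated ring carbon responds to which phenyl group it carries, but all three groups were phenyl rings. Benzyl has one heavy atom fewer than 2-ethylphenyl and the same single six-membered aromatic ring of carbon, yet the change gives an at least 190-fold higher number from compound 3 to compound 4 (2.29 log units; beyond the scatter), and the step from 2-fluorophenyl gives an at least 130-fold higher number from compound 2 to compound 4 (2.12 log units; beyond the scatter). Even the 3-methoxyphenyl group, the poorest of the earlier three, compares favourably, with an at least 10-fold higher number from compound 1 to compound 4 (1.02 log units; beyond the scatter), so among the compounds shown, benzyl is the only group that reaches the limit and the phenyl groups all remain measurable.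

On these data alone, the true size of these steps remains open, since each has a bound on one side only, and a single benzyl cannot separate the effect of the added carbon from the absence of a ring substituent. An unsubstituted phenyl, a 2-ethylbenzyl or a 2-fluorobenzyl on the same carbon would be needed to tell these two readings apart.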